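Hydroxyphenyl placement beside a trifluoromethoxy partner

A few compounds are considered here, and "the series" means these few. Any claim that something is new, unique, unknown or untested is made for them only; others in the source may bear on it.

Measured so far:
compound 1 `Oc1ccc(-c2cc(-c3ccc(C(F)(F)F)cc3)cc(-c3ccc(O)cc3)n2)cc1`, in a functional assay on HCT-15 cells (Homo sapiens) for inhibition (on this read-out lower numbers stand for stronger inhibition and higher numbers for weaker inhibition), a limit of > 50000 nM.
compound 2 `Oc1ccc(-c2cc(-c3ccc(OC(F)(F)F)cc3)cc(-c3cccc(O)c3)n2)cc1`, in this assay 1380 nM.

In this assay compound 1 reaches only the limit of the assay, > 50000 nM, so no number stands for it. Among the measured compounds shown here, compound 2 is the only compound with a measured number, at 1380 nM. The other value shown, that of compound 1, is a limit (the limit of > 50000 nM in this assay, at which 1 of the 2 values shown sits). Compound 3 `Oc1ccc(-c2cc(-c3ccc(OC(F)(F)F)cc3)cc(-c3ccc(O)cc3)n2)cc1` has the same atoms as compound 2, joined differently: 4-hydroxyphenyl in place of 3-hydroxyphenyl on an aromatic carbon. For the measured compounds named here, no step between two measured compounds covers this change, so there is no measured step to lean on. Compound 1, which also carries two 4-hydroxyphenyl groups, gives only the limit > 50000 nM; this weighs toward weaker inhibition expected for compound 3 rather than no change beyond the scatter. The step from compound 2 to compound 3 is expected at a 7.2-fold higher number from compound 2 to compound 3 (0.86 log units; beyond the scatter), a loss beyond the scatter. Compound 3 is estimated at 10000 nM, within 2000 nM to 50000 nM, with a fair chance that only a limit is reported.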

Compound 3, half-maximal inhibitory concentration: 13900 nM
Estimate against measurement, compound 3: 1.4-fold (0.14 log units) below, and the stated range covers the measured number.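

In this assay, the hydroxyl placement on the aromatic carbon next to the ring nitrogen now has a measured size: with the trifluoromethoxy partner held constant, 4-hydroxyphenyl in place of 3-hydroxyphenyl gives a 10-fold higher number from compound 2 to compound 3 (1.00 log units; beyond the scatter). With both 4-hydroxyphenyl groups held constant, trifluoromethoxy in place of trifluoromethyl gives an at least 3.5-fold lower number from compound 1 to compound 3 (0.55 log units; beyond the scatter), so a pair of 4-hydroxyphenyl groups does not by itself put a compound at the limit of this assay. This second step gives a bound and not an exact size, since compound 1 stands at a limit: the limit of > 50000 nM in this assay, at which 1 of the 3 values shown sits.

The compounds shown leave open whether 3-hydroxyphenyl would also give a lower number than 4-hydroxyphenyl in the trifluoromethyl series, and whether the change from trifluoromethyl to trifluoromethoxy would have a similar effect alongside 3-hydroxyphenyl. They also leave open how inhibition would respond if an amine or a carboxylic acid took the place of the hydroxyl on this ring, so the comparison at this position rests on the two hydroxyphenyl isomers alone.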